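Swapping a fluorinated phenyl for pyridyl on a styrylchromone

The source may hold more compounds than are shown below. What is called first, only, known or untested is meant among the compounds shown, and "the series" means these compounds.

Three compounds share one core and differ only in the ring at the far end of the two-carbon double-bonded chain. Compound 1 `COc1cc(OC)c2c(=O)cc(/C=C/c3ccc(C(F)(F)F)cc3)oc2c1` carries a trifluoromethyl group and in a functional assay on HeLa cells (Homo sapiens) for antiproliferative activity, read by MTT assay, with a stated time of 12 h (on this read-out higher numbers stand for weaker inhibition and lower numbers for stronger inhibition), gives 19000 nM. Compound 2 `COc1cc(OC)c2c(=O)cc(/C=C/c3ccc(F)cc3)oc2c1` carries a fluoro group instead and gives 14200 nM, the lowest of the two plain numbers, though the step of a 1.3-fold lower number from compound 1 to compound 2 (0.13 log units; within the scatter) lies within the scatter. Compound 3 `COc1cc(OC)c2c(=O)cc(/C=C/c3ccc(OC(F)(F)F)cc3)oc2c1` carries trifluoromethoxy and gives only a limit, > 40000 nM. The steps of an at least 2.1-fold higher number from compound 1 to compound 3 (0.32 log units; beyond the scatter) and an at least 2.8-fold higher number from compound 2 to compound 3 (0.44 log units; beyond the scatter) are the only ones beyond the scatter.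

Compound 4 `COc1cc(OC)c2c(=O)cc(/C=C/c3ccncc3)oc2c1` is the untested member; its change from compound 2 is pyridin-4-yl in place of 4-fluorophenyl on a double-bonded chain carbon bound to a double-bonded chain carbon. Within the data shown here, none of the measured steps touches this change: all three keep a carbon-only ring and vary only its substituent, so they offer no guide to putting a nitrogen into the ring itself. With compound 2 at 14200 nM as the anchor, the step of a 1.3-fold higher number from compound 2 to compound 4 (0.10 log units; within the scatter) is expected to stay near the scatter. Compound 4 is therefore estimated at 18000 nM, between 6000 nM and 40000 nM.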

Compound 4, half-maximal inhibitory concentration: 18800 nM
Compound 4: middle estimate off by 1.0-fold (0.02 log units), on the low side, within the range that was stated.
By their numbers in this assay, from the lowest: compounds 2, 4 and 1 (each within the scatter of the next). At a limit, above all of these: compound 3.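

Until now, every change at this position kept a carbon-only ring, whereas here the ring itself changes: in this assay, pyridin-4-yl in place of 4-fluorophenyl gives a 1.3-fold higher number from compound 2 to compound 4 (0.12 log units; within the scatter) and so leaves the read-out essentially where it was. On a double-bonded chain carbon bound to a double-bonded chain carbon, then, a ring with one hetero atom and one hydrogen-bond acceptor cannot be told apart from the fluorinated carbon ring on this read-out. Nothing shown here bears on why the two rings read alike.

The compounds shown leave open whether pyridin-3-yl or pyridin-2-yl would read the same as pyridin-4-yl, or whether a phenyl ring carrying an amine or a carboxylic acid would move the number. Going by these compounds, it also remains open whether this swap would behave the same way on a different core.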